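Aryl group change from compound 3 to compound 4

A few compounds are considered here, and "the series" means these few. Any claim that something is new, unique, unknown or untested is made for them only; others in the source may bear on it.

Read-out: a functional assay on A549 cells (Homo sapiens) for inhibition, read by CCK-8 assay, with a stated time of 72 h, tested at 1 uM; on this read-out higher numbers stand for more inhibition of growth at the one concentration tested and lower numbers for less inhibition of growth
- compound 1 `CN(C)C(=O)c1cc2cnc(Nc3ccc(NC(=O)C4(C(=O)Nc5ccc(F)cc5)CC4)cc3)nc2n1C1CCCC1` gives 86.6%
- compound 2 `COC(=O)c1ccc(NC(=O)C2(C(=O)Nc3ccc(Nc4ncc5cc(C(=O)N(C)C)n(C6CCCC6)c5n4)cc3)CC2)cc1` gives 77.1%
- compound 3 `CN(C)C(=O)c1cc2cnc(Nc3ccc(NC(=O)C4(C(=O)Nc5cccc(F)c5)CC4)cc3)nc2n1C1CCCC1` gives 33.2%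

Compound 3 stands lowest of the three, beyond the scatter from both others. Among the compounds with values here, compound 4 `COc1ccc(NC(=O)C2(C(=O)Nc3ccc(Nc4ncc5cc(C(=O)N(C)C)n(C6CCCC6)c5n4)cc3)CC2)cc1` carries 4-methoxyphenyl in place of 3-fluorophenyl on an amide-type nitrogen as its only change. Only the group at that place changes in a number 53.4 percentage points lower from compound 1 to compound 3 (beyond the scatter) and in a number 43.9 percentage points lower from compound 2 to compound 3 (beyond the scatter), both large. The remaining step, a number 9.5 percentage points lower from compound 1 to compound 2 (within the scatter), stays within the scatter. Within the data shown here, no measured compound carries 4-methoxyphenyl, so a large rise in this assay is expected with wide uncertainty. The expected change is a number 38.8 percentage points higher from compound 3 to compound 4 (beyond the scatter) by this estimate. For compound 4 the estimated value is 72%, with an expected range from 45% to 90% overall.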

Compound 4, percent growth inhibition at one concentration: 74.4%
Beside the measured number, compound 4's estimate is 2.4 percentage points below it; measured number inside the range.
By their numbers in this assay, from the lowest: compound 3; then compounds 4, 2 and 1 (each within the scatter of the next, the first and the last beyond it).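

In this assay, the step of a number 41.2 percentage points higher from compound 3 to compound 4 (beyond the scatter) shows that compound 3 is the low point among these aryl groups on the amide-type nitrogen, since 4-methoxyphenyl restores a high number. The groups are not fully interchangeable: the step of a number 2.7 percentage points lower from compound 2 to compound 4 (within the scatter) separates methoxy from methoxycarbonyl by no more than the scatter, whereas the step of a number 12.2 percentage points lower from compound 1 to compound 4 (beyond the scatter) separates methoxy from fluoro by a modest amount. No evidence available here explains these differences.

Still open, from the compounds shown here alone, is whether 3-methoxyphenyl would fall as 3-fluorophenyl does. Also open, going by these compounds, is how 4-aminophenyl or 4-carboxyphenyl would read at this place.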